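A Carboxy Group in Place of a Sulfone Chain

This account rests on a few compounds, and the source may have more. Where it says the series, first, only, none or still open, it means among the compounds named here.

Of the compounds shown here, three have been measured in a functional assay on cells for antagonist activity at C-C chemokine receptor type 4 (Homo sapiens), read by fluorescence and calcium flux, with stated times of 2.5 s and 45 s; a lower number here means a stronger inhibitor, a higher number a weaker inhibitor. Compound 1 `Cc1nn([C@H](C)c2ccc(Cl)cc2Cl)c2nc(N3CC[C@H](N4CCC[C@H]4CCS(C)(=O)=O)[C@H](C)C3)cnc12` gives 104 nM, the lowest of the three numbers, and it stands beyond the scatter from both of the others. Compound 2 `CC1CN(c2cnc3c(C#N)nn(C(C)c4ccc(Cl)cc4Cl)c3n2)CCC1N1CCCCC1` gives 251 nM, while compound 3 `CC1CN(c2cnc3c(C(N)=O)nn(C(C)c4ccc(Cl)cc4Cl)c3n2)CCC1N1CCCCC1` gives 228 nM; the step of a 1.1-fold lower number from compound 2 to compound 3 (0.04 log units; within the scatter) lies within the scatter, so these two read alike.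

Compound 4 `Cc1nn([C@H](C)c2ccc(Cl)cc2Cl)c2nc(N3CC[C@H](N4CCC[C@H]4C(=O)O)[C@H](C)C3)cnc12` differs from compound 1 in a single place: carboxy in place of 2-(methylsulfonyl)ethyl on a saturated ring carbon. Going by the values given here, no measured step touches this part of the structure; the only step in hand, a 1.1-fold lower number from compound 2 to compound 3 (0.04 log units; within the scatter), concerns a different part and was small. Among the compounds with values here, the expectation therefore rests on no direct precedent and stays wide. Compound 4 is expected to give 250 nM, within 60 nM to 1000 nM, an expected step of a 2.4-fold higher number from compound 1 to compound 4 (0.38 log units; beyond the scatter).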

Compound 4, half-maximal inhibitory concentration: 670 nM
Compound 4: middle estimate off by 2.7-fold (0.43 log units), on the low side; low and high end bracket the measured number.
By their numbers in this assay, from the lowest: compound 1; then compounds 3 and 2 (each within the scatter of the next); then compound 4.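

Swapping 2-(methylsulfonyl)ethyl for carboxy on this saturated ring carbon gives a 6.4-fold higher number from compound 1 to compound 4 (0.81 log units; beyond the scatter) and shows that the number responds to what this position carries. Going by these compounds alone, the earlier step changed a different part of the structure and stayed within the scatter, so this is the first clear change seen here. Nothing measured here explains the rise.

Going by these compounds, the change replaces both the chain and its end group, so their separate contributions remain unknown. A 2-carboxyethyl chain or an aminomethyl group at this carbon could help separate them.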